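Aryl amine variation on the shared core

The source may report more compounds than this note shows. Statements on the series, on what has been measured and on what is new or still open speak of the compounds shown alone.

Compound 2 `Cc1ccc(NC2=CC(=O)c3c(nc4n3[C@H]3OC[C@@H](O)[C@H]3OC4)C2=O)cc1C` has the highest number of the three in a functional assay on HeLa cells (Homo sapiens) for inhibition, read by sulforhodamine B assay (a higher number here means a weaker inhibitor, a lower number a stronger inhibitor), giving 4320 nM, but compound 1 `O=C1C=C(Nc2ccc(I)cc2)C(=O)c2c1nc1n2[C@H]2OC[C@@H](O)[C@H]2OC1` with 4070 nM and compound 3 `CCc1ccc(NC2=CC(=O)c3nc4n(c3C2=O)[C@H]2OC[C@@H](O)[C@H]2OC4)cc1` with 3990 nM both lie within the scatter of it, so the three are not separable. Compound 4 `CCOc1ccccc1NC1=CC(=O)c2c(nc3n2[C@H]2OC[C@@H](O)[C@H]2OC3)C1=O` differs from compound 2 by 2-ethoxyphenyl in place of 3,4-dimethylphenyl on an amine nitrogen. Within the data shown here, the only measured step between neighbours, a 1.0-fold lower number from compound 1 to compound 3 (0.01 log units; within the scatter), swaps one group on an aromatic carbon and stays within the scatter; no measured step exchanges the whole aryl group, so the expectation rests on the flatness of the series. Compound 4 is expected to give a step of a 1.0-fold higher number from compound 2 to compound 4 (0.02 log units; within the scatter), nothing beyond the scatter. The estimate for compound 4 in this assay is 4500 nM, with a range from 2000 nM to 10000 nM.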

Compound 4, half-maximal inhibitory concentration: 8300 nM
Compound 4: the middle estimate sits 1.8-fold (0.27 log units) below what was measured; the measured number falls inside the stated range.
By their numbers in this assay, from the lowest: compounds 3, 1, 2 and 4 (each within the scatter of the next, the first and the last beyond it).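

Exchanging the whole aryl group on the amine nitrogen, with 2-ethoxyphenyl entering for 3,4-dimethylphenyl, gives in this assay a 1.9-fold higher number from compound 2 to compound 4 (0.28 log units; within the scatter) and is the largest listed step in the series, yet it remains inside the scatter. This position therefore tolerates a change of the whole aryl group that adds a hydrogen-bond acceptor, with no step beyond the scatter. Nothing available explains the size of this step.

Still open, from the compounds shown here alone, is whether a carboxylic acid or a basic amine on the aryl group would produce a step beyond the scatter. Equally open, going by these compounds, is whether a saturated ring such as cyclohexyl can replace the aryl group.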